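A fluorinated branched group replaces butyl on the pyridine

The compounds below may be only part of what the source reports. "The series", "measured", "known", "first", "only" and "open" are said of these compounds alone.

The shared core of compound 3, `CCCCc1ccc(-c2nc(-c3ccc(CCC(=O)O)cc3C)no2)nc1`, carries a butyl group on its six-membered aromatic ring with one nitrogen. In a functional assay on CHO cells for agonist activity at sphingosine 1-phosphate receptor 5 (Homo sapiens), read by GTPgammaS binding (a higher number here means that more compound is needed for the effect, a lower number that less compound is needed), compound 3 gives only a limit, > 10000 nM, and no number. Among the three measured compounds, compound 3 is the one sitting at the limit of > 10000 nM in this assay, at which 1 of the 3 values shown sits. For comparison, compound 1, `Cc1ccccc1-c1noc(-c2ccc(C3CCCCC3)cc2)n1`, gives 266 nM in this assay, and compound 2, `Cc1cc(CCC(=O)O)ccc1-c1noc(-c2ccc(OC(C)C)c(C(F)(F)F)c2)n1`, gives 40 nM.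

Compound 4, `Cc1cc(CCC(=O)O)ccc1-c1noc(-c2ccc(C(F)(F)C(C)C)cn2)n1`, differs from compound 3 in one place: 1,1-difluoro-2-methylpropyl in place of butyl on an aromatic carbon. Among the compounds with values here, no step between measured compounds shows how this kind of exchange acts in this assay, so nothing measured tells the size or direction of the step. Since compound 3 is known only as a limit, the expected step is itself uncertain, and the author expects a step toward less compound needed, an at least 6.6-fold lower number from compound 3 to compound 4 (0.82 log units; beyond the scatter), carrying a wide range. For compound 4 the estimated value in this assay is 1500 nM, expected between 150 nM and 10000 nM.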

Compound 4, half-maximal effective concentration: 820 nM
The estimate for compound 4 lay 1.8-fold (0.26 log units) above the measured number; the measured number falls inside the stated range.
By their numbers in this assay, from the lowest: compound 2; then compound 1; then compound 4. At a limit, above all of these: compound 3.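

In this assay, within the data shown here, the exchange of butyl for 1,1-difluoro-2-methylpropyl on an aromatic carbon, para to a large group, gives an at least 12-fold lower number from compound 3 to compound 4 (1.08 log units; beyond the scatter) and is the only step measured at this position. It shows that a change in this one substituent alone can bring a compound from a limit to a measured number, on the shared core with the six-membered aromatic ring with 1 nitrogen. From the compounds shown here alone, the true size of the step stays unknown, because the reading for compound 3 is a limit and not a number: the limit of > 10000 nM in this assay, at which 1 of the 4 values shown sits.

The compounds shown leave open whether the two fluorine atoms or the branching carries the step, since the exchange brings in both at once. They also leave open how an unfluorinated 2-methylpropyl group or a longer chain would read at this position.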